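A few compounds are considered here, and "the series" means these few. Any claim that something is new, unique, unknown or untested is made for them only; others in the source may bear on it.

Measured in a functional assay on HUVEC cells (Homo sapiens) for inhibition; on this read-out higher numbers stand for weaker inhibition and lower numbers for stronger inhibition:
- compound 1 `CCNC(=O)Nc1ccc(N(C)c2ccnc(Nc3ccc(CS(C)(=O)=O)cc3)n2)cc1`: 27 nM
- compound 2 `CN(c1ccc(NC(=O)NC2CCCC2)cc1)c1ccnc(Nc2cccc(CS(C)(=O)=O)c2)n1`: 1 nM
- compound 3 `CN(C)CCNC(=O)Nc1ccc(N(C)c2ccnc(Nc3cccc(CS(C)(=O)=O)c3)n2)cc1`: 530 nM

Of these three, compound 3 has the highest number, and so the weakest inhibition. Compound 4 `CN(C)CCNC(=O)Nc1ccc(N(C)c2ccnc(Nc3ccc(CS(C)(=O)=O)cc3)n2)cc1` differs from it in one place: 4-((methylsulfonyl)methyl)phenyl in place of 3-((methylsulfonyl)methyl)phenyl on a nitrogen on an aromatic ring. Among the measured compounds shown here, the only measured step, a 530-fold higher number from compound 2 to compound 3 (2.72 log units; beyond the scatter), concerns a different place, so it does not size this swap. Compound 1 also carries 4-((methylsulfonyl)methyl)phenyl and gives 27 nM, but it differs from compound 3 on the amide-type nitrogen too, so that gap cannot be credited to this change alone. With no direct evidence, only a small drop is expected, and the estimate means a 1.8-fold lower number from compound 3 to compound 4 (0.25 log units; within the scatter). For compound 4 the estimated value is 300 nM, with an expected range of 50 nM to 1200 nM.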

Compound 4, half-maximal inhibitory concentration: 2980 nM
For compound 4 the middle estimate is 9.9-fold (1.00 log units) below the measured one; measured number above the stated range.
By their numbers in this assay, from the lowest: compound 2; then compound 1; then compound 3; then compound 4.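

In this assay, the same atoms joined differently do not behave alike: 4-((methylsulfonyl)methyl)phenyl in place of 3-((methylsulfonyl)methyl)phenyl gives a modest loss (a 5.6-fold higher number from compound 3 to compound 4 (0.75 log units; beyond the scatter)), so where this group sits on the ring matters. With the 4-((methylsulfonyl)methyl)phenyl group held fixed, adding dimethylamino to the chain gives a much larger loss (a 110-fold higher number from compound 1 to compound 4 (2.04 log units; beyond the scatter)). No measurement here explains either step. Still open, from the compounds shown here alone, is whether the ring swap has a similar size with cyclopentyl on the amide-type nitrogen. Also open, going by these compounds, is whether a primary amine or a longer chain behaves like dimethylamino.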